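The source may report more compounds than this note shows. Statements on the series, on what has been measured and on what is new or still open speak of the compounds shown alone.

Measured in a toxicity assay on HT-29 cells (Homo sapiens) for cytotoxicity; a higher number here means that more compound is tolerated, a lower number that less compound is tolerated:
Compound 1 `CN1C(=S)[C@@H](NC(=O)c2nc(Cc3ccccc3)n(CCCCC#N)n2)COc2ccccc21`: > 100000 nM (a limit)
Compound 2 `CN1C(=S)[C@@H](NC(=O)c2nc(Cc3ccccc3)n(C3CCN(C(=O)OC(C)(C)C)C3)n2)COc2ccccc21`: > 100000 nM (a limit)

In this assay compound 2 stands at > 100000 nM, which is a limit of the assay and not a number. The data so far hold only (the limit of > 100000 nM in this assay, at which 2 of the 2 values shown sit). Within the data shown here, the one measured step, a step that the two limits leave unreadable from compound 1 to compound 2, has no readable size, so it offers nothing to carry forward. Compound 3 `CN1C(=S)[C@@H](NC(=O)c2nc(Cc3ccccc3)n(C3CCNC3)n2)COc2ccccc21` differs from compound 2 by hydrogen in place of tert-butoxycarbonyl on an amine nitrogen in a ring. Among the measured compounds shown here, no measured step covers this change. Starting from compound 2 at > 100000 nM, no step beyond the scatter is expected in this assay, and no direction can be expected. The expected step is a number no higher from compound 2 to compound 3 (the limit leaves the size open), and it is only an estimate. For compound 3 the estimated value is 100000 nM, with an expected range from 30000 nM to 200000 nM.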

Compound 3, half-maximal cytotoxic concentration: > 100000 nM
Compound 3 gave a limit, no number; the forecaster's own chance of this, stated with the estimate: 75%; the middle value lies on the limit itself.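

In this assay compound 3 gives > 100000 nM, which is a limit of the assay and not a number. Among these compounds, no new step to compound 3 can be read from compound 1 or compound 2. The compounds shown leave open where the half-maximal cytotoxic concentration of any of the three lies, and whether hydrogen in place of tert-butoxycarbonyl shifts it at all.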